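Swapping the amide end of compound 2 for a carboxyphenyl group

The source may hold more compounds than are shown below. What is called first, only, known or untested is meant among the compounds shown, and "the series" means these compounds.

Of the compounds shown here, three sharing one core have been tested in an assay on U2OS cells for inhibition of secreted frizzled-related protein 1 (Homo sapiens), read by a luciferase reporter, with a stated time of 18 h; a lower number here means that less compound is needed, a higher number that more compound is needed for the effect. Compound 1 `O=C(c1ccccc1)N1CCC(NS(=O)(=O)c2cc(S(=O)(=O)c3ccccc3)ccc2C(F)(F)F)CC1` gives 250 nM. Compound 2 `O=C(c1ccc(Cl)cc1)N1CCC(NS(=O)(=O)c2cc(S(=O)(=O)c3ccccc3)ccc2C(F)(F)F)CC1` gives 1800 nM, the highest number of the three. Compound 3 `O=C(c1cccnc1)N1CCC(NS(=O)(=O)c2cc(S(=O)(=O)c3ccccc3)ccc2C(F)(F)F)CC1` gives 120 nM, the lowest.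

Two steps describe how compound 2 is reached or left. Adding a chloro gives a 7.2-fold higher number from compound 1 to compound 2 (0.86 log units; beyond the scatter), so the chloro on the phenyl costs potency. Replacing the whole 4-chlorophenyl by pyridin-3-yl gives a 15-fold lower number from compound 2 to compound 3 (1.18 log units; beyond the scatter), the largest shift seen here.

Compound 4 `O=C(O)c1ccc(N2CCC(NS(=O)(=O)c3cc(S(=O)(=O)c4ccccc4)ccc3C(F)(F)F)CC2)cc1` changes compound 2 in this way: 4-carboxyphenyl in place of (4-chlorophenyl)carbonyl on an amine nitrogen in a ring. This step differs from both measured ones: the chloro leaves, as in the reverse of the step from compound 1 to compound 2, but the carbonyl also leaves, and a carboxylic acid enters, neither of which any measured pair covers. Removing the chloro alone would be expected to bring the number down toward compound 1; the loss of the carbonyl and the arrival of the acid have no precedent among these compounds, so the estimate is kept wide. Compound 4 is therefore expected at 800 nM, within a range from 150 nM to 5000 nM, an expected step of a 2.3-fold lower number from compound 2 to compound 4 (0.35 log units; beyond the scatter).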

Compound 4, half-maximal effective concentration: 230 nM
Estimate against measurement, compound 4: 3.5-fold (0.54 log units) above, within the range that was stated.
By their numbers in this assay, from the lowest: compounds 3, 4 and 1 (each within the scatter of the next, the first and the last beyond it); then compound 2.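

In this assay, the amine nitrogen in the ring of the shared core turns out not to need a carbonyl on it: with 4-carboxyphenyl attached there instead of (4-chlorophenyl)carbonyl, the result is a clear gain (a 7.8-fold lower number from compound 2 to compound 4 (0.89 log units; beyond the scatter)). The earlier compounds shown here only varied the group on an amide carbonyl, whereas compound 4 shows that the number can stay in the same range without that carbonyl, since it cannot be told apart from the two better amides (a 1.1-fold lower number from compound 1 to compound 4 (0.04 log units; within the scatter); a 1.9-fold higher number from compound 3 to compound 4 (0.28 log units; within the scatter)). No supporting measurement is available to explain why this exchange is tolerated or why the chloro-bearing amide, compound 2, stands apart.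

Because the carbonyl, the chloro and the carboxylic acid all change in a single step, the compounds shown cannot assign the gain to any one of them. A plain phenyl on the same nitrogen would test the loss of the carbonyl without the acid, while a 4-carboxybenzoyl group would test the acid with the carbonyl kept, and a methyl ester in place of the carboxylic acid would ask whether the acid's hydrogen matters.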